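Benzamide thioethers: methyl to ethyl on the aryl ring

The source may hold more compounds than are shown below. What is called first, only, known or untested is meant among the compounds shown, and "the series" means these compounds.

Measured so far:
compound 1 `Nc1ccccc1NC(=O)c1ccc(CSc2ccc(C(F)(F)F)cn2)cc1`: 16.5%
compound 2 `Cc1ccc(SCc2ccc(C(=O)Nc3ccccc3N)cc2)cc1`: 79.2%
compound 3 `Nc1ccccc1NC(=O)/C=C/c1ccc(CSc2ccc(C(F)(F)F)cn2)cc1`: 6.82%

In a functional assay on HeLa cells (Homo sapiens) for inhibition, read by CCK-8 assay, with a stated time of 72 h, tested at 8 uM (on this read-out higher numbers stand for more inhibition of growth at the one concentration tested and lower numbers for less inhibition of growth), compound 2 gives 79.2%, the highest of the three numbers. Compound 1 gives 16.5%, a number beyond the scatter below that of compound 2, and compound 3 gives 6.82%, also beyond the scatter below it. Among the compounds with values here, no two measured compounds differ in only one place, so no single step has been seen.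

Compound 4 `CCc1ccc(SCc2ccc(C(=O)Nc3ccccc3N)cc2)cc1` differs from compound 2 by methyl in place of hydrogen on a saturated chain carbon bound to an aromatic carbon. Within the data shown here, no measured pair shows a change of this kind. The step of a number 5.2 percentage points lower from compound 2 to compound 4 (within the scatter) is expected to be small, with no direction that would stand out beyond the scatter. Compound 4 is therefore expected to give about 74%, within a range from 52% to 90%.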

Compound 4, percent growth inhibition at one concentration: 71%
Compound 4: middle estimate off by 3 percentage points, on the high side; low and high end bracket the measured number.
By their numbers in this assay, from the lowest: compounds 3 and 1 (each within the scatter of the next); then compounds 4 and 2 (each within the scatter of the next).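

In this assay, within the data shown here, the change from 4-methylphenyl to 4-ethylphenyl gives a number 8.2 percentage points lower from compound 2 to compound 4 (within the scatter) as the first step that can be read at a single place. At this position, methyl and ethyl are not told apart by this read-out, and growth inhibition stays in the range of compound 2. No measured finding bears on this result. Still open, from the compounds shown here alone, is whether a longer chain such as propyl keeps that level at this position. Going by these compounds, an amine or a carboxylic acid on the same ring is equally open.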